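The source may hold more compounds than are shown below. What is called first, only, known or untested is meant among the compounds shown, and "the series" means these compounds.

Working notes on a small thioether series sharing one core. Compound 1 `CC(C)Sc1nc(O)cc(C(C)c2ccccc2)n1` carries isopropyl on the sulfur. In a functional assay on MT4 cells (Homo sapiens) for cytotoxicity (on this read-out higher numbers stand for lower toxicity in this test and lower numbers for higher toxicity in this test), compound 1 reaches only a limit, > 200000 nM. Compound 2 `CC(c1ccccc1)c1cc(O)nc(SC2CCCC2)n1` differs from compound 1 by cyclopentyl in place of isopropyl on a sulfur and in this assay compound 2 gives 159000 nM. The resulting step of an at least 1.2-fold lower number from compound 1 to compound 2 (0.09 log units; that floor lies within the scatter) is known only as a floor because of the limit of > 200000 nM in this assay, at which 1 of the 3 values shown sits. Compound 3 `CC(C)Sc1nc(O)cc(C(C)c2cccc3ccccc23)n1` keeps isopropyl on the sulfur; how its core differs from the core of compound 1 is not broken down here. In this assay compound 3 gives 119000 nM, a value whose gap to compound 2 lies within the scatter. Compound 4 `CC(c1cc(O)nc(SC2CCCC2)n1)c1cccc2ccccc12` is not yet measured; it differs from compound 3 by cyclopentyl in place of isopropyl on a sulfur, the same change as from compound 1 to compound 2, at the same place on the sulfur. For compound 4 a step of similar small size is expected, a 1.2-fold lower number from compound 3 to compound 4 (0.08 log units; within the scatter), resting on the measured step of an at least 1.2-fold lower number from compound 1 to compound 2 (0.09 log units; that floor lies within the scatter). Compound 4 is therefore estimated at 100000 nM in this assay, with a likely range from 60000 nM to 170000 nM.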

Compound 4, half-maximal cytotoxic concentration: 93000 nM
Beside the measured number, compound 4's estimate is 1.1-fold (0.03 log units) above it; low and high end bracket the measured number.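

In this assay, cyclopentyl in place of isopropyl on a sulfur gives a 1.3-fold lower number from compound 3 to compound 4 (0.11 log units; within the scatter), so on the core of compound 3 the change stays inside the usual scatter. Set beside the earlier step, the change shows no size beyond the scatter on either of the two cores, which is all that can be said about carrying it across: the same change on two cores in this assay, an at least 1.2-fold lower number (0.09 log units; that floor lies within the scatter) from compound 1 to compound 2 and a 1.3-fold lower number (0.11 log units; within the scatter) from compound 3 to compound 4; the limit leaves it open whether they differ. Equal transfer is not shown, because compound 1 stands at a limit and the earlier step is therefore only a floor: the limit of > 200000 nM in this assay, at which 1 of the 4 values shown sits.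

The compounds shown cover only two cores and only isopropyl and cyclopentyl on the sulfur, so the reading does not extend to other cores or other groups at that place. On these data alone, whether a longer chain on the sulfur, or such a chain ending in an amine or a carboxylic acid, would leave this read-out within the scatter remains open.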